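The source may hold more compounds than are shown below. What is called first, only, known or untested is meant among the compounds shown, and "the series" means these compounds.

The measured compounds so far:
compound 1, `CC(C)c1ccc(N2C(=O)C=CC2OCC(F)(F)F)cc1`; in a functional assay on MDA-MB-231 cells (Homo sapiens) for inhibition (a lower number here means a stronger inhibitor, a higher number a weaker inhibitor), compound 1 gives 6640 nM.
compound 2, `O=C1C=CC(OCC(F)(F)F)N1c1ccc([N+](=O)[O-])cc1`; in this assay compound 2 gives 2830 nM.
compound 3, `O=C1C=CC(OCC(F)(F)F)N1c1ccc(C(F)(F)F)cc1`; in this assay compound 3 gives 2300 nM.

Within the data shown here, compound 3 has the lowest number of the three, but the gap to compound 2 is within the scatter (a 1.2-fold lower number from compound 2 to compound 3 (0.09 log units; within the scatter)), so these two cannot be ranked against each other; only the step of a 2.9-fold lower number from compound 1 to compound 3 (0.46 log units; beyond the scatter) is beyond the scatter. Compound 4, `O=C1C=CC(OCC(F)(F)F)N1c1ccc(Br)cc1`, differs from compound 3 in one place: bromo in place of trifluoromethyl on an aromatic carbon. Among the measured compounds shown here, no measured step exchanges these two groups. The steps that exist change the group at this same place and are modest at most: a 2.3-fold lower number from compound 1 to compound 2 (0.37 log units; beyond the scatter) and a 2.9-fold lower number from compound 1 to compound 3 (0.46 log units; beyond the scatter), while a 1.2-fold lower number from compound 2 to compound 3 (0.09 log units; within the scatter) shows that two different groups at this place can give numbers within the scatter. Compound 4 is therefore expected to stay close to compound 3, the expected step being a 1.2-fold higher number from compound 3 to compound 4 (0.09 log units; within the scatter), with no clear direction. The estimate for compound 4 in this assay is 2800 nM, with a range from 1200 nM to 6500 nM.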

Compound 4, half-maximal inhibitory concentration: 7570 nM
For compound 4 the middle estimate is 2.7-fold (0.43 log units) below the measured one; measured number above the stated range.
By their numbers in this assay, from the lowest: compounds 3 and 2 (each within the scatter of the next); then compounds 1 and 4 (each within the scatter of the next).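

In this assay, among these compounds, the exchange of trifluoromethyl for bromo gives a 3.3-fold higher number from compound 3 to compound 4 (0.52 log units; beyond the scatter) and is the largest step seen at this place so far, so a change on this aromatic carbon does not always stay within the scatter. Bromo also separates from nitro with a 2.7-fold higher number from compound 2 to compound 4 (0.43 log units; beyond the scatter) but cannot be told apart from isopropyl with a 1.1-fold higher number from compound 1 to compound 4 (0.06 log units; within the scatter) and so the four groups form two pairs, trifluoromethyl with nitro and bromo with isopropyl. Nothing measured here explains why the groups pair this way.

Going by these compounds, all four compounds vary only this one place, so how an amine or a carboxylic acid would fall there remains open. On these data alone, whether the two pairs would persist with a longer chain in place of the ether chain on the shared core also remains open.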